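Compound 3 to compound 4: a carbonyl substituent swap

The compounds below may be only part of what the source reports. "The series", "measured", "known", "first", "only" and "open" are said of these compounds alone.

Values in a toxicity assay on THP-1 cells (Homo sapiens) for inhibition (a higher number here means that more compound is tolerated, a lower number that less compound is tolerated), each one a limit of the assay:
compound 1 `COc1ccc(-c2cnc(NC(=O)c3ncc[nH]3)n2C)cc1`: > 100000 nM
compound 2 `COc1ccc(-c2cnc(NC(=O)c3ccc(Br)cc3)n2C)cc1`: > 100000 nM
compound 3 `COc1ccc(-c2cnc(NC(=O)c3cccc(OC)c3)n2C)cc1`: > 100000 nM

Compound 3 stands at > 100000 nM, which is a limit and not a number. Compound 4 `COc1ccc(-c2cnc(NC(=O)c3ccccc3Br)n2C)cc1` carries 2-bromophenyl in place of 3-methoxyphenyl on a carbonyl carbon with the rest unchanged. The nearest evidence is a step that the two limits leave unreadable from compound 2 to compound 3, and a step that the two limits leave unreadable from compound 1 to compound 2 and a step that the two limits leave unreadable from compound 1 to compound 3 also bear on it. None of the three has a readable size. No step beyond the scatter is therefore expected in this assay, in either direction. The expected step is a number no higher from compound 3 to compound 4 (the limit leaves the size open) as an estimate. Compound 4 is expected at 100000 nM, with an estimated range from 50000 nM to 200000 nM and most likely a limit as the report.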

Compound 4, half-maximal cytotoxic concentration: > 100000 nM
Compound 4 ended at the assay's limit; the forecaster's own chance of this, stated with the estimate: 85%; the middle value lies on the limit itself.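

In this assay, among these compounds, compound 4 gives > 100000 nM, a limit and not a number, and no step among compound 1, compound 2, compound 3 and compound 4 can be read. The compounds shown leave open whether any carbonyl substituent changes the tolerated concentration, as all of them sit at one value: the limit of > 100000 nM in this assay, at which 4 of the 4 values shown sit.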